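Aryl amide substituent change: compound 2 to compound 4

This account rests on a few compounds, and the source may have more. Where it says the series, first, only, none or still open, it means among the compounds named here.

Compound 2 `CCN1CCN(c2cc(C)c3cc(NC(=O)c4ccccc4OC)ccc3n2)CC1` holds the highest number of the three measured in a functional assay on MCF7 cells (Homo sapiens) for antiproliferative activity, read by MTT assay, with a stated time of 72 h; a higher number here means a weaker inhibitor, a lower number a stronger inhibitor: compound 2 gives 13200 nM. Compound 1 `CCN1CCN(c2cc(C)c3cc(NC(=O)c4cc(Cl)cc(Cl)c4)ccc3n2)CC1` gives 6090 nM, and compound 3 `Cc1cc(N2CCN(C)CC2)nc2ccc(NC(=O)c3ccc(Cl)c(Cl)c3)cc12` gives 3000 nM. Compound 3 differs from compound 2 in two places, so only the two values are set side by side, and the clearly lower number belongs to compound 3.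

Compound 4 `CCN1CCN(c2cc(C)c3cc(NC(=O)c4ccccc4Br)ccc3n2)CC1` is compound 2 with one change: bromo in place of methoxy on an aromatic carbon. A single heavy atom enters where two leave, and the one hydrogen-bond acceptor of the methoxy is lost.

Within the data shown here, the only measured step that bears on this change is a 2.2-fold higher number from compound 1 to compound 2 (0.34 log units; beyond the scatter), in which the methoxyphenyl amide gave the higher number than a dichlorophenyl amide. Compound 4 moves back toward a halogenated aryl amide, and both halogenated examples, compound 1 and compound 3, sit below compound 2. A modest step to a lower number is therefore expected, a 1.9-fold lower number from compound 2 to compound 4 (0.28 log units; within the scatter), roughly undoing the earlier methoxy step, though the halogen pattern here is not one already measured.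

For compound 4 the estimated value is 7000 nM, with a range from 3000 nM to 16000 nM.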

Compound 4, half-maximal inhibitory concentration: 27500 nM
Compound 4: the middle estimate sits 3.9-fold (0.59 log units) below what was measured; the whole stated range lies below it.
By their numbers in this assay, from the lowest: compound 3; then compound 1; then compound 2; then compound 4.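

In this assay, the step to bromo at this place, ortho to a large group, goes upward: a 2.1-fold higher number from compound 2 to compound 4 (0.32 log units; beyond the scatter). A halogen on the aryl amide therefore does not bring a lower number by itself, and compound 4 goes against the earlier picture of halogenated amides sitting below compound 2, while the change of aryl pattern also counts, with a 4.5-fold higher number from compound 1 to compound 4 (0.65 log units; beyond the scatter) setting the 2-bromophenyl amide clearly above the 3,5-dichlorophenyl amide. No measurement on hand bears on why the number rises, so the step stands as an observation only.

Still open, as far as these compounds go, is whether the higher numbers of compound 2 and compound 4 belong to substitution at this ortho place as such or to the particular groups there, a question that a fluoro group or a plain unsubstituted phenyl amide would help to settle. Among these compounds, also open is how an amine or a carboxylic acid on this same aromatic carbon would read, since methoxy and bromo are the only two groups compared at this place.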